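This account rests on a few compounds, and the source may have more. Where it says the series, first, only, none or still open, it means among the compounds named here.

Measured in a functional assay on MCF7 cells (Homo sapiens) for antiproliferative activity; on this read-out lower numbers stand for stronger inhibition and higher numbers for weaker inhibition:
- Compound 1 `CC(C)=CCc1cc(C(=O)Nc2cc3ccc(OCCCN(C)C(C)C)c(C)c3oc2=O)ccc1O`: 1050 nM
- Compound 2 `CC(C)=CCc1cc(C(=O)Nc2cc3ccc(OCCCN(C)C4CCCCC4)c(C)c3oc2=O)ccc1O`: 1080 nM

Compound 2 stands level with compound 1, since their two values lie within the usual scatter. Compound 3 `CC(C)=CCc1cc(C(=O)Nc2cc3ccc(OCCCN(C)c4ccccc4)c(C)c3oc2=O)ccc1O` has phenyl in place of cyclohexyl on an amine nitrogen. For the measured compounds named here, the only measured step bearing on this is a 1.0-fold higher number from compound 1 to compound 2 (0.01 log units; within the scatter), with cyclohexyl in place of isopropyl on an amine nitrogen. Neither group in that step is aromatic, so it guides this change only loosely. No step beyond the scatter is therefore expected in this assay, in either direction. The expected step is a 1.1-fold higher number from compound 2 to compound 3 (0.05 log units; within the scatter). Compound 3 is estimated at 1200 nM, with an expected range of 500 nM to 3000 nM.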

Compound 3, half-maximal inhibitory concentration: > 50000 nM
Compound 3: only a limit was reported (the forecaster's own chance of this, stated with the estimate: 3%); at least 41-fold (1.61 log units) between middle value and limit.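

In this assay, swapping isopropyl for cyclohexyl on the amine nitrogen changed little, but phenyl on that same nitrogen gives an at least 46-fold higher number from compound 2 to compound 3 (1.66 log units; beyond the scatter) and an at least 47-fold higher number from compound 1 to compound 3 (1.67 log units; beyond the scatter). At this position, then, the aromatic ring parts sharply from the two saturated groups, even though cyclohexyl and phenyl have the same count of heavy atoms. The figure for compound 3 is a limit, not a measured number: the limit of > 50000 nM in this assay, at which 1 of the 3 values shown sits. Going by these compounds, whether a benzyl group or a pyridyl ring on that nitrogen would behave like phenyl or like cyclohexyl stays open. On these data alone, the true size of the step to compound 3 also stays open.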